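This account rests on a few compounds, and the source may have more. Where it says the series, first, only, none or still open, it means among the compounds named here.

Compound 1 `CC(O)(CSc1cccc(C(F)(F)F)c1)C(=O)Nc1cccc(S(F)(F)(F)(F)F)c1` and compound 2 `CC(O)(CSc1ccccc1C(F)(F)F)C(=O)Nc1cccc(S(F)(F)(F)(F)F)c1` share one core and differ only in the change (2-(trifluoromethyl)phenyl in place of 3-(trifluoromethyl)phenyl on a sulfur). In a functional assay on VCaP cells (Homo sapiens) for antiproliferative activity, read by propidium iodide staining, with a stated time of 96 h (on this read-out higher numbers stand for weaker inhibition and lower numbers for stronger inhibition), compound 1 gives 20200 nM, and compound 2 gives 21000 nM, which amounts to a 1.0-fold higher number from compound 1 to compound 2 (0.02 log units; within the scatter). Compound 3 `CC(O)(CS(=O)(=O)c1cccc(C(F)(F)F)c1)C(=O)Nc1cccc(S(F)(F)(F)(F)F)c1` is built on a different core; how its core differs from that of compound 1 is not broken down here. In this assay compound 3 gives 35500 nM. Compound 4 `CC(O)(CS(=O)(=O)c1ccccc1C(F)(F)F)C(=O)Nc1cccc(S(F)(F)(F)(F)F)c1` stands to compound 3 as compound 2 stands to compound 1, through the same kind of change, (2-(trifluoromethyl)phenyl in place of 3-(trifluoromethyl)phenyl on a sulfonyl sulfur), although here the place is a sulfonyl sulfur rather than a sulfur. For compound 4 a step of a 1.0-fold higher number from compound 3 to compound 4 (0.01 log units; within the scatter) in this assay is expected, an expectation that rests on a 1.0-fold higher number from compound 1 to compound 2 (0.02 log units; within the scatter). Compound 4 is therefore estimated at 36000 nM, with a likely range from 20000 nM to 65000 nM.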

Compound 4, half-maximal inhibitory concentration: 40800 nM
For compound 4 the middle estimate is 1.1-fold (0.05 log units) below the measured one, within the range that was stated.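

Putting 2-(trifluoromethyl)phenyl in place of 3-(trifluoromethyl)phenyl on a sulfonyl sulfur gives, in this assay, a 1.1-fold higher number from compound 3 to compound 4 (0.06 log units; within the scatter). Set beside the same change on the core of compound 1, the step shows no difference that can be told from the scatter: the same change on two cores in this assay, a 1.0-fold higher number (0.02 log units; within the scatter) from compound 1 to compound 2 and a 1.1-fold higher number (0.06 log units; within the scatter) from compound 3 to compound 4, 1.1-fold (0.04 log units) apart, within the scatter of two such steps. This shows that the change stays without a readable effect on these two cores, but both steps are too small to show that a change with a real effect would carry over, and it says nothing about other cores.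

The compounds shown leave open how a nitrile or a methoxy group in place of the trifluoromethyl would read in this assay. They also leave open what a sulfinyl sulfur or an amine nitrogen in place of the sulfur would give.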